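Fluorine on the benzoic acid ring of compound 2

The compounds below may be only part of what the source reports. "The series", "measured", "known", "first", "only" and "open" are said of these compounds alone.

Measured compounds:
Compound 1, `O=C(O)Cc1ccc(C=C2CCN(C(=O)C(C3CCCCC3)C3CCCCC3)CC2)c(F)c1`: 38 nM
Compound 2, `O=C(O)c1ccc(C=C2CCN(C(=O)C(c3ccccc3)c3ccccc3)CC2)cc1`: 370 nM

Of the compounds shown here, two have been measured in an assay on Prostate gland for inhibition of 3-oxo-5-alpha-steroid 4-dehydrogenase 2 (Rattus norvegicus); on this read-out higher numbers stand for weaker inhibition and lower numbers for stronger inhibition. Compound 1 gives 38 nM. Compound 2 gives 370 nM, the higher of the two numbers, and the gap between them is beyond the scatter; the two structures differ in several places, so the numbers alone cannot say which difference matters.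

Compound 3, `O=C(O)c1ccc(C=C2CCN(C(=O)C(c3ccccc3)c3ccccc3)CC2)c(F)c1`, has not yet been measured in this assay. It is compound 2 with one change, (fluoro in place of hydrogen on an aromatic carbon). Read one bond further out, 4-carboxyphenyl becomes 4-carboxy-2-fluorophenyl, the same pattern carried by compound 1. Among the measured compounds shown here, no measured pair separates this change from the others, so its effect is unknown here. The account expects a small step toward a lower number, a 1.9-fold lower number from compound 2 to compound 3 (0.27 log units; within the scatter), possibly within the scatter. Compound 3 is estimated at 200 nM, between 70 nM and 600 nM.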

Compound 3, half-maximal inhibitory concentration: 1100 nM
The estimate for compound 3 lay 5.5-fold (0.74 log units) below the measured number; the whole stated range lies below it.
By their numbers in this assay, from the lowest: compound 1; then compound 2; then compound 3.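

In this assay, fluoro in place of hydrogen on this aromatic carbon can now be read on its own, and the change gives a 3.0-fold higher number from compound 2 to compound 3 (0.47 log units; beyond the scatter), a modest step but one beyond the scatter. On the core of compound 2, then, this position is sensitive to the addition of a single fluorine atom, and turning 4-carboxyphenyl into 4-carboxy-2-fluorophenyl weakens inhibition rather than strengthening it. Nothing among the data shown gives a cause for this step.

Going by these compounds, whether the loss belongs to fluoro itself or would also follow a chloro, methyl or methoxy group on the same carbon remains open. Also open is whether the change would run the same way on the core of compound 1, which has no partner lacking the fluoro among the compounds shown.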